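The compounds below may be only part of what the source reports. "The series", "measured", "known", "first", "only" and "open" are said of these compounds alone.

Compound 1 `Cc1cc(-n2cccn2)cc(C(=O)NNS(=O)(=O)c2ccccc2)c1F` gives 1.25 h in an ADME assay on microsomes from liver (Homo sapiens) for metabolic stability, read by HPLC, using NADPH, with a stated time of 60 min, tested at 1 uM, in the presence of a further agent that is not named here; a lower number here means that the compound disappears faster, a higher number that the compound lasts longer.
Compound 2 `Cc1cc(-c2ccccn2)cc(C(=O)NNS(=O)(=O)c2ccccc2)c1F` gives 1.08 h in this assay.
Compound 3 `Cc1cc(-n2nccn2)cc(C(=O)NNS(=O)(=O)c2ccccc2)c1F` gives 1.02 h in this assay.

The three measured compounds share one core and differ only in the group carried on an aromatic carbon of the carbon-only six-membered ring. Compound 3, carrying the 2H-1,2,3-triazol-2-yl group, stands with its number close to both neighbours: a 1.2-fold lower number from compound 1 to compound 3 (0.09 log units; within the scatter) and a 1.1-fold lower number from compound 2 to compound 3 (0.02 log units; within the scatter), so the three half-lives cannot be told apart on these data.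

Compound 4 `C=CCOc1cc(C)c(F)c(C(=O)NNS(=O)(=O)c2ccccc2)c1` is the next compound, not yet measured. Its change from compound 3 is allyloxy in place of 2H-1,2,3-triazol-2-yl on an aromatic carbon. Of the measured steps, a 1.2-fold lower number from compound 1 to compound 2 (0.06 log units; within the scatter), a 1.2-fold lower number from compound 1 to compound 3 (0.09 log units; within the scatter) and a 1.1-fold lower number from compound 2 to compound 3 (0.02 log units; within the scatter) all exchange one aromatic heterocycle for another, and none of them swaps a ring for an open chain with a double bond, so none bears directly on this step; what they do show is that changing the substituent at this position has so far left the half-life within the scatter. On that basis compound 4 is expected to give a number not far from compound 3, with the step estimated as a 1.2-fold lower number from compound 3 to compound 4 (0.08 log units; within the scatter) and wide uncertainty. The estimated half-life for compound 4 is 0.85 h, expected to fall between 0.3 h and 2.2 h.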

Compound 4, half-life: 0.4 h
Beside the measured number, compound 4's estimate is 2.1-fold (0.33 log units) above it; the range from low to high includes it.
By their numbers in this assay, from the lowest: compound 4; then compounds 3, 2 and 1 (each within the scatter of the next).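

In this assay, the position para to a fluoro group proves able to move the half-life, which the three aromatic heterocycles had not shown: allyloxy in place of 2H-1,2,3-triazol-2-yl gives a 2.6-fold lower number from compound 3 to compound 4 (0.41 log units; beyond the scatter). The same holds when allyloxy replaces the other two rings, with pyridin-2-yl giving a 2.7-fold lower number from compound 2 to compound 4 (0.43 log units; beyond the scatter) and 1H-pyrazol-1-yl giving a 3.1-fold lower number from compound 1 to compound 4 (0.49 log units; beyond the scatter), so compound 4 alone separates from the group and has the shortest half-life of the four, though all three steps are modest. Nothing measured here explains the drop, and the change removes the ring and brings in an oxygen link and a double bond all at once, so the data cannot say which of these matters.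

From the compounds shown here alone, whether a propoxy group, which keeps the chain length without the double bond, or a shorter methoxy group would give a number like that of compound 4 remains open. Also open, going by these compounds, is how a phenyl ring, an amine or a carboxylic acid at this position would compare with the aromatic heterocycles and with allyloxy.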